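The source may hold more compounds than are shown below. What is called first, only, known or untested is meant among the compounds shown, and "the series" means these compounds.

Notes on the amine tail of the series.

Compound 1 `COc1cc2c(Nc3nc4ccc(C(=O)Nc5c(C)cc(C)cc5C)cc4s3)ncnc2cc1OCCCN1CCC(C)CC1` gives 7000 nM in a functional assay on DLD-1 cells (Homo sapiens) for cytotoxicity, read by WST assay, with a stated time of 72 h; a lower number here means a stronger inhibitor, a higher number a weaker inhibitor. Compound 2 `COc1cc2c(Nc3nc4ccc(C(=O)Nc5c(C)cccc5Cl)cc4s3)ncnc2cc1OCCCN1CCCCC1C` gives 6700 nM in this assay, and the two values sit within the scatter of each other. Compound 3 `COc1cc2c(Nc3nc4ccc(C(=O)Nc5c(C)cccc5C)cc4s3)ncnc2cc1OCCCN1CCC(C)CC1` gives only a limit, > 100000 nM, in this assay. The step of an at least 14-fold higher number from compound 1 to compound 3 (1.15 log units; beyond the scatter) rests on (the limit of > 100000 nM in this assay, at which 1 of the 3 values shown sits), so its true size is not known.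

Compound 4 `CCN(CC)CCCOc1cc2ncnc(Nc3nc4ccc(C(=O)Nc5c(C)cc(C)cc5C)cc4s3)c2cc1OC` carries diethylamino in place of 4-methylpiperidin-1-yl on a saturated chain carbon, three bonds along the chain from an oxygen on an aromatic ring. Among the measured compounds shown here, no measured step touches this position: the single measured step changes a methyl on the aryl amide, and compound 2 differs from compound 1 in two places at once, its amine ring and its aryl amide. Compound 4 is therefore expected to show no step beyond the scatter, no change at the digits printed from compound 1 to compound 4 (within the scatter), in this assay. The estimate for compound 4 in this assay is 7000 nM, expected to fall between 3000 nM and 16000 nM.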

Compound 4, half-maximal inhibitory concentration: 6800 nM
Compound 4: middle estimate off by 1.0-fold (0.01 log units), on the high side, within the range that was stated.
By their numbers in this assay, from the lowest: compounds 2, 4 and 1 (each within the scatter of the next). At a limit, above all of these: compound 3.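

In this assay, among the compounds shown here, replacing 4-methylpiperidin-1-yl with diethylamino gives a 1.0-fold lower number from compound 1 to compound 4 (0.01 log units; within the scatter), the first reading of the amine tail in which nothing else changes. For the compounds shown here, on the saturated chain carbon, three bonds along the chain from an oxygen on an aromatic ring, this open-chain amine therefore matches the ring amine within the scatter, at least on the aryl amide of compound 1, whereas the only step beyond the scatter so far lies on the aryl amide. Nothing measured gives a cause for this result.

Still open, as far as these compounds go, is whether a morpholin-4-yl or a dimethylamino group, or a chain longer than 3-(diethylamino)propyl, would keep the value in the same range. Also open, from the compounds shown here alone, is whether diethylamino would match the ring amine on other aryl amides, such as that of compound 2.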